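This account rests on a few compounds, and the source may have more. Where it says the series, first, only, none or still open, it means among the compounds named here.

Measured compounds:
compound 1, `CCCCCCCCCCCCC(C)(C)C(=O)Nc1c(C)cc(C)c2c1OC(C)(C)C2` — 33 nM in an assay for inhibition of acyl-CoA:cholesterol acyltransferase (Oryctolagus cuniculus), using microsomes; on this read-out lower numbers stand for stronger inhibition and higher numbers for weaker inhibition
compound 2, `Cc1cc(C)c(NC(=O)C(C)(C)CCCCc2ccccc2)c2c1CC(C)(C)O2` — 210 nM
compound 3, `Cc1cc(C)c(NC(=O)C(C)(C)CCCCCCc2ccccc2)c2c1CC(C)(C)O2` — 81 nM

Compound 3 stands second highest of the three numbers in this assay: its two steps are a 2.5-fold higher number from compound 1 to compound 3 (0.39 log units; beyond the scatter) and a 2.6-fold lower number from compound 2 to compound 3 (0.41 log units; beyond the scatter). Compound 4, `Cc1cc(C)c(NC(=O)C(C)(C)CCCCCOc2ccc(Cl)cc2)c2c1CC(C)(C)O2`, differs from compound 3 by 4-chlorophenoxy in place of benzyl on a saturated chain carbon, six bonds along the chain from a carbonyl carbon. The measured steps that bear on this all concern what sits on the chain: a 6.4-fold higher number from compound 1 to compound 2 (0.80 log units; beyond the scatter), a 2.5-fold higher number from compound 1 to compound 3 (0.39 log units; beyond the scatter) and a 2.6-fold lower number from compound 2 to compound 3 (0.41 log units; beyond the scatter), each modest. Among the measured compounds shown here, no measured step brings in an oxygen or a chlorine, so the data give no direct guide there. Compound 4 is therefore expected to give a number close to compound 3, with a step of a 1.0-fold lower number from compound 3 to compound 4 (0.01 log units; within the scatter) that may fall within the scatter, estimated at 80 nM in this assay, within 30 nM to 250 nM.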

Compound 4, half-maximal inhibitory concentration: 150 nM
Compound 4: the middle estimate sits 1.9-fold (0.27 log units) below what was measured, within the range that was stated.
By their numbers in this assay, from the lowest: compound 1; then compounds 3, 4 and 2 (each within the scatter of the next, the first and the last beyond it).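

In this assay, 4-chlorophenoxy on a saturated chain carbon, six bonds along the chain from a carbonyl carbon, brings in an oxygen and a chlorine with no step beyond the scatter against either phenyl-ended chain: a 1.9-fold higher number from compound 3 to compound 4 (0.27 log units; within the scatter), and a 1.4-fold lower number from compound 2 to compound 4 (0.15 log units; within the scatter). Among the compounds shown here, only the step from the all-carbon chain is beyond the scatter: a 4.5-fold higher number from compound 1 to compound 4 (0.66 log units; beyond the scatter). Nothing measured here accounts for these results. Going by these compounds, the oxygen and the chlorine enter together, and their separate shares remain open. On these data alone, how a plain phenoxy or an amine at this place would read also remains open.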